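Glycosylated benzohydrazones: a nitro group replaces chlorine

This account rests on a few compounds, and the source may have more. Where it says the series, first, only, none or still open, it means among the compounds named here.

Measured compounds:
compound 1 `N#Cc1cccc(/C=N/NC(=O)c2ccc(O[C@@H]3O[C@H](CO)[C@@H](O)[C@H](O)[C@H]3O)cc2)c1`: 6.17%
compound 2 `O=C(N/N=C/c1cccc(Cl)c1)c1ccc(O[C@@H]2O[C@H](CO)[C@@H](O)[C@H](O)[C@H]2O)cc1`: 5.02%

In a functional assay on MDA-MB-231 cells (Homo sapiens) for inhibition, read by MTT assay, with a stated time of 24 h, tested at 100 uM (a lower number here means less inhibition, a higher number more inhibition at the concentration tested (going by the name of the read-out)), compound 1 gives 6.17%, and compound 2 gives 5.02%. Within the data shown here, the single measured step is a number 1.2 percentage points lower from compound 1 to compound 2 (within the scatter). Compound 2 thus stands at the low end of the two numbers, but its gap to compound 1 is within the scatter, so the two cannot be told apart.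

Compound 3 `O=C(N/N=C/c1ccc([N+](=O)[O-])cc1)c1ccc(O[C@@H]2O[C@H](CO)[C@@H](O)[C@H](O)[C@H]2O)cc1` differs from compound 2 in one place: 4-nitrophenyl in place of 3-chlorophenyl on a carbon with a double bond to nitrogen. Among the measured compounds shown here, the only step that bears on this change is the exchange of chloro for cyano on the same carbon, which left the read-out unchanged within the scatter. For the measured compounds named here, no measured step involves 4-nitrophenyl. Compound 3 is therefore expected to show no step beyond the scatter, a number 1 percentage points higher from compound 2 to compound 3 (within the scatter). The estimate for compound 3 is 6%, in a range from 0% to 18%.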

Compound 3, a percentage reported as inhibition, at one concentration (the size of the read-out at that concentration, not a potency): 7.12%
Estimate against measurement, compound 3: 1.1 percentage points below, within the range that was stated.
By their numbers in this assay, from the lowest: compounds 2, 1 and 3 (each within the scatter of the next).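

Unlike the earlier exchange of chloro for cyano, this change replaces the whole aryl group on the carbon with a double bond to nitrogen. In this assay it gives a number 2.1 percentage points higher from compound 2 to compound 3 (within the scatter) and a number 1 percentage points higher from compound 1 to compound 3 (within the scatter) as the step from the cyano analogue. The 3-chlorophenyl, 3-cyanophenyl and 4-nitrophenyl compounds therefore cannot be told apart at this position, and nothing at hand offers an explanation for that.

The compounds shown leave open whether a different kind of group at this carbon, such as an aminophenyl, a carboxyphenyl or a longer alkyl chain, would move the read-out beyond the scatter. From the compounds shown here alone, the rest of the molecule is the same in all three compounds, so what a change there would do also remains open.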